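The source may hold more compounds than are shown below. What is called first, only, known or untested is meant among the compounds shown, and "the series" means these compounds.

Liver microsomes offer a quick first look at how fast a compound is cleared, and the measure used here is an ADME assay on microsomes from liver (Mus musculus) for metabolic stability, read by LC-MS, with a stated time of 40 min, tested at 0.5 uM; on this read-out higher numbers stand for fast clearance and lower numbers for slow clearance. On that scale compound 1 (`O=C(Nc1cccc(S(=O)(=O)C2CCCC2)c1)c1cccnc1N1CCC(F)(F)CC1`) gives > 399 mL.min-1.g-1, which is a limit of the assay and not a number. Compound 2 (`CC(C)(C)NS(=O)(=O)c1cccc(NC(=O)c2ccc(NC3(CO)CC3)cc2N2CCC3(CC2)CC3)n1`) gives a true number in this assay, namely 58 mL.min-1.g-1, but its structure is quite different and no single change connects it to compound 1.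

The next compound stays much closer. Compound 3 (`O=C(Nc1cccc(S(=O)(=O)C2CCCC2)c1)c1cccnc1N1CCCCC1`) keeps the core of compound 1 and carries piperidin-1-yl in place of 4,4-difluoropiperidin-1-yl on an aromatic carbon, next to the ring nitrogen (piperidin-1-yl in place of 4,4-difluoropiperidin-1-yl on an aromatic carbon). Among the measured compounds shown here, no measured pair here shows what this swap does. The only anchor for an expectation is compound 1 at > 399 mL.min-1.g-1, again a limit. In this assay the expected change is a step that the limit leaves unreadable from compound 1 to compound 3, which is none beyond the usual scatter of repeats, so clearance is expected to stay fast. Compound 3 is estimated at 400 mL.min-1.g-1 with an expected range from 200 mL.min-1.g-1 to 800 mL.min-1.g-1.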

Compound 3, intrinsic clearance in microsomes: > 399 mL.min-1.g-1
Compound 3 ended at the assay's limit; the forecaster's own chance of this, stated with the estimate: 60%; the middle value is on the limit's open side.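

Compound 1 and compound 3 both give a limit in this assay and not a number, so no step can be read between them, because the read-out ends there: the limit of > 399 mL.min-1.g-1 in this assay, at which 2 of the 3 values shown sit. The compounds shown leave open how far apart their clearances truly lie, and whether piperidin-1-yl in place of 4,4-difluoropiperidin-1-yl changes clearance at all.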